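Trading a Chloro for a Methoxy on the Aryl Ring

The source may hold more compounds than are shown below. What is called first, only, known or untested is meant among the compounds shown, and "the series" means these compounds.

Measured so far, in an assay on isolated protein for inhibition of Fatty-acid amide hydrolase 1 (Homo sapiens), read by fluorescence, with a stated time of 30 min; on this read-out lower numbers stand for stronger inhibition and higher numbers for weaker inhibition:
Compound 1 `CCOC(=O)c1cc(-c2cccc(OC(=O)NC3CCCCC3)c2)n(-c2ccc(OC)cc2)n1` gives 103 nM
Compound 2 `NC(=O)c1cc(-c2cccc(OC(=O)NC3CCCCC3)c2)n(-c2ccccc2)n1` gives 169 nM
Compound 3 `NC(=O)c1cc(-c2cccc(OC(=O)NC3CCCCC3)c2)n(-c2ccc(Cl)cc2)n1` gives 174 nM

Compound 3 carries the highest number of the three, but this says little: compound 2 lies within the scatter of it, and even compound 1, the furthest away, is still within the scatter. Among the measured compounds shown here, the three compounds therefore stand as one group, with no member that can be called stronger or weaker than another.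

Compound 4 `COc1ccc(-n2nc(C(N)=O)cc2-c2cccc(OC(=O)NC3CCCCC3)c2)cc1` is the next step. It differs from compound 3 by methoxy in place of chloro on an aromatic carbon. For the measured compounds named here, only one measured step touches this position on the ring: a 1.0-fold higher number from compound 2 to compound 3 (0.01 log units; within the scatter), which stayed within the scatter. Compound 1 carries the same methoxy-bearing ring as compound 4, but it also differs from the others at another part of the shared core, so its value alone, not a clean step, is what it offers; that value sits close to the other two.

With nothing pointing beyond the scatter, the step from compound 3 to compound 4 is expected to be small, a 1.2-fold lower number from compound 3 to compound 4 (0.06 log units; within the scatter). Compound 4 is therefore estimated at 150 nM, within a range from 70 nM to 320 nM.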

Compound 4, half-maximal inhibitory concentration: 743 nM
Estimate against measurement, compound 4: 5.0-fold (0.69 log units) below; measured number above the stated range.
By their numbers in this assay, from the lowest: compounds 1, 2 and 3 (each within the scatter of the next); then compound 4.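

The ring position looked indifferent while only hydrogen and chloro had been compared, and chloro in place of hydrogen gave a 1.0-fold higher number from compound 2 to compound 3 (0.01 log units; within the scatter) in this assay. Methoxy shows that this position can matter in the amide compounds, with a 4.3-fold higher number from compound 3 to compound 4 (0.63 log units; beyond the scatter) when it replaces chloro and a 4.4-fold higher number from compound 2 to compound 4 (0.64 log units; beyond the scatter) when it replaces hydrogen. The methoxy-bearing ring does not always come with a high number, however: the group on the carbonyl carbon also counts, as amino in place of ethoxy gives a 7.2-fold higher number from compound 1 to compound 4 (0.86 log units; beyond the scatter) with the 4-methoxyphenyl ring held constant.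

Compound 1 is the only compound here with ethoxy on the carbonyl, so the compounds shown leave open whether methoxy would weaken inhibition with ethoxy there too, and whether a methyl or a hydroxyl group on the ring would behave like chloro or like methoxy. Nothing measured here explains why methoxy separates from hydrogen and chloro in the amide compounds.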